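Replacing the hydroxyphenyl of compound 1 with a difluorophenyl

The compounds below may be only part of what the source reports. "The series", "measured", "known", "first", "only" and "open" are said of these compounds alone.

Compound 1 `CN(C)CCn1cnnc1-c1cc(Oc2ccc(NC(=O)N/N=C/c3ccc(O)cc3)cc2F)ccn1` is measured in a functional assay on NCI-H460 cells (Homo sapiens) for cytotoxicity, read by MTT assay, with a stated time of 72 h (a higher number here means a weaker inhibitor, a lower number a stronger inhibitor), at 1780 nM. Of the three numbers shown it is the lowest; compound 2 `CN(C)CCn1cnnc1-c1cc(Oc2ccc(NC(=O)N/N=C/c3ccc(F)cc3)cc2F)ccn1` gives 1980 nM and lies within the scatter of it, while compound 3 `Cn1ncnc1-c1cc(Oc2ccc(NC(=O)N/N=C/c3ccccc3)cc2F)ccn1`, on a different core, gives 52200 nM, far beyond the scatter. Compound 4 `CN(C)CCn1cnnc1-c1cc(Oc2ccc(NC(=O)N/N=C/c3ccc(F)cc3F)cc2F)ccn1` differs from compound 1 by 2,4-difluorophenyl in place of 4-hydroxyphenyl on a carbon with a double bond to nitrogen. Going by the values given here, the one measured step that bears on this change is a 1.1-fold higher number from compound 1 to compound 2 (0.05 log units; within the scatter), a swap on the same aromatic ring that left the number essentially unchanged. Among the compounds with values here, no step covers a second fluorine. He therefore expects no step beyond the scatter, a 1.2-fold higher number from compound 1 to compound 4 (0.07 log units; within the scatter), and estimates compound 4 at 2100 nM, within a range of 1000 nM to 4500 nM.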

Compound 4, half-maximal inhibitory concentration: 1930 nM
Compound 4: the middle estimate sits 1.1-fold (0.04 log units) above what was measured, within the range that was stated.
By their numbers in this assay, from the lowest: compounds 1, 4 and 2 (each within the scatter of the next); then compound 3.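

In this assay, the 2,4-difluorophenyl has no hydrogen-bond donor, unlike the 4-hydroxyphenyl, yet the exchange stays within the scatter (a 1.1-fold higher number from compound 1 to compound 4 (0.04 log units; within the scatter)). The second fluorine likewise makes no difference beyond the scatter (a 1.0-fold lower number from compound 2 to compound 4 (0.01 log units; within the scatter)), so on the carbon with a double bond to nitrogen, all three aryl groups in compound 1, compound 2 and compound 4 give comparable numbers. No evidence shown accounts for this.

Going by these compounds, it remains open whether this tolerance extends to a carboxylic acid or an amine on the ring. A longer chain in place of the ring is equally untested here.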